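A few compounds are considered here, and "the series" means these few. Any claim that something is new, unique, unknown or untested is made for them only; others in the source may bear on it.

In a functional assay on HCT-116 cells (Homo sapiens) for antiproliferative activity, read by MTT assay, with a stated time of 24 h (a higher number here means a weaker inhibitor, a lower number a stronger inhibitor), compound 1 (`COc1ccc(-c2noc(C3CCNCC3)n2)cc1OC1CCCC1`) gives 1540 nM and compound 2 (`COc1ccc(-c2noc(-c3ccc(F)cc3)n2)cc1OC1CCCC1`) gives 210000 nM as the higher of the two numbers, which makes compound 2 the weaker inhibitor of the pair. Compound 3 (`COc1ccc(-c2noc(-c3ccc(O)cc3)n2)cc1OC1CCCC1`) differs from compound 2 at one substituent (hydroxy in place of fluoro on an aromatic carbon), with hydroxy in place of fluoro on an aromatic carbon, para to a large group. For the measured compounds named here, the one measured step (a 140-fold higher number from compound 1 to compound 2 (2.13 log units; beyond the scatter)) is large, but it exchanged piperidin-4-yl for 4-fluorophenyl, so it offers only a weak guide to this smaller swap. Going by the values given here, no measured pair covers fluoro and hydroxy, so only a modest move towards a lower number is expected. The estimated step (a 2.3-fold lower number from compound 2 to compound 3 (0.37 log units; beyond the scatter)) is expected to remain well short of the measured one. For compound 3 the expected value is 90000 nM (estimated range 20000 nM to 300000 nM).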

Compound 3, half-maximal inhibitory concentration: 270 nM
For compound 3 the middle estimate is 330-fold (2.52 log units) above the measured one; the measured number lies below the stated range.
By their numbers in this assay, from the lowest: compound 3; then compound 1; then compound 2.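

In this assay, the exchange of a single atom at this place, para to a large group, carries a step as large as the replacement of the whole piperidin-4-yl group: hydroxy in place of fluoro gives a 780-fold lower number from compound 2 to compound 3 (2.89 log units; beyond the scatter) on an otherwise unchanged structure. An aryl group here is therefore not weak in itself, since 4-hydroxyphenyl in place of piperidin-4-yl gives a 5.7-fold lower number from compound 1 to compound 3 (0.76 log units; beyond the scatter) and so reverses the direction seen with 4-fluorophenyl. Nothing on hand accounts for the size of this change.

The compounds shown leave open how methoxy, an amine or a carboxylic acid would read at this place. Also open, as far as these compounds go, is whether the step from fluoro to hydroxy depends on the rest of the core of compound 3.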